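Adding a methoxy to the benzoyl ring of compound 1

This account rests on a few compounds, and the source may have more. Where it says the series, first, only, none or still open, it means among the compounds named here.

Compound 1, `O=C(Nc1cccc(/C=C/C(=O)c2nc3ccccc3[nH]2)c1)c1ccccc1`, is the parent of this small set. In a functional assay on HCT-116 cells (Homo sapiens) for antiproliferative activity, read by MTT assay, with a stated time of 48 h (on this read-out lower numbers stand for stronger inhibition and higher numbers for weaker inhibition), compound 1 gives 2440 nM. Compound 2, `O=C(/C=C/c1cccc(NC(=O)c2ccccc2Cl)c1)c1nc2ccccc2[nH]1`, gives 1280 nM, and compound 3, `O=C(Nc1cccc(/C=C/C(=O)c2nc3ccccc3[nH]2)c1)c1cccc(C(F)(F)F)c1`, gives 3360 nM. Compound 1 thus stands second highest of the three numbers, with compound 3 nearest and compound 2 furthest, yet both neighbours lie within the scatter: a 1.9-fold lower number from compound 1 to compound 2 (0.28 log units; within the scatter) and a 1.4-fold higher number from compound 1 to compound 3 (0.14 log units; within the scatter). Only the comparison between the two substituted compounds reaches further, a 2.6-fold higher number from compound 2 to compound 3 (0.42 log units; beyond the scatter), and even that is modest.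

Compound 4, `COc1ccc(C(=O)Nc2cccc(/C=C/C(=O)c3nc4ccccc4[nH]3)c2)cc1`, has not yet been measured. It differs from compound 1 in one place: methoxy in place of hydrogen on an aromatic carbon. Going by the values given here, no measured step involves a methoxy, and none puts a group para to a large group on this ring. The two steps from compound 1 that bear on it, adding chloro and adding trifluoromethyl to the same benzoyl ring, each stayed within the scatter, one in each direction. The expectation is therefore no step beyond the scatter in this assay, estimated as a 1.1-fold lower number from compound 1 to compound 4 (0.04 log units; within the scatter). Compound 4 is expected to give about 2200 nM, with a range from 1000 nM to 5000 nM.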

Compound 4, half-maximal inhibitory concentration: 4880 nM
Beside the measured number, compound 4's estimate is 2.2-fold (0.35 log units) below it; measured number inside the range.
By their numbers in this assay, from the lowest: compounds 2, 1, 3 and 4 (each within the scatter of the next, the first and the last beyond it).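

In this assay, going by these compounds alone, the methoxy gives the first reading at the place para to a large group, and a 2.0-fold higher number from compound 1 to compound 4 (0.30 log units; within the scatter) shows that this addition, like the chloro and trifluoromethyl additions, does not carry the number beyond the scatter. Set against the other substituted compounds, the picture is split: a 1.5-fold higher number from compound 3 to compound 4 (0.16 log units; within the scatter) also stays within the scatter, while a 3.8-fold higher number from compound 2 to compound 4 (0.58 log units; beyond the scatter) goes beyond it, though only modestly, so the 4-methoxyphenyl and 2-chlorophenyl amides can be told apart and the 4-methoxyphenyl and 3-(trifluoromethyl)phenyl amides cannot. No measurement is available that would explain any of these steps.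

The 2-chlorophenyl, 3-(trifluoromethyl)phenyl and 4-methoxyphenyl amides differ in both the group and its place on the ring, so these compounds cannot separate the effect of one from the other, and a 2-methoxyphenyl or 4-chlorophenyl amide would be needed to do so. From the compounds shown here alone, it also remains open whether a different kind of group at the place para to a large group, such as an amine, a carboxylic acid or a longer chain like ethoxy, would move the number clearly beyond the scatter from the parent.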